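From 4-methylphenyl to 2-methylphenyl

The source may hold more compounds than are shown below. What is called first, only, known or untested is meant among the compounds shown, and "the series" means these compounds.

Compound 1 `Nc1nc(N)c2cc(CSC(=S)N3CCN(c4ccccc4)CC3)ccc2n1`: 2970 nM
Compound 2 `Nc1nc(N)c2cc(CSC(=S)N3CCN(c4ccc(O)cc4)CC3)ccc2n1`: 4210 nM
Compound 3 `Cc1ccc(N2CCN(C(=S)SCc3ccc4nc(N)nc(N)c4c3)CC2)cc1`: 2190 nM

All three values come from a functional assay on A549 cells (Homo sapiens) for antiproliferative activity, read by MTT assay, with a stated time of 72 h; a higher number here means a weaker inhibitor, a lower number a stronger inhibitor. Compound 3 cannot be told apart from the other two, as a 1.4-fold lower number from compound 1 to compound 3 (0.13 log units; within the scatter) and a 1.9-fold lower number from compound 2 to compound 3 (0.28 log units; within the scatter) show. Compound 4 `Cc1ccccc1N1CCN(C(=S)SCc2ccc3nc(N)nc(N)c3c2)CC1` is still unmeasured. It has 2-methylphenyl in place of 4-methylphenyl on an amine nitrogen in a ring. For the measured compounds named here, no measured step moves a group in this way, so the evidence is indirect. Methyl in place of hydrogen gave a 1.4-fold lower number from compound 1 to compound 3 (0.13 log units; within the scatter), and hydroxy in place of hydrogen gave a 1.4-fold higher number from compound 1 to compound 2 (0.15 log units; within the scatter). With steps this small, no change beyond the scatter is expected in this assay. Compound 4 is expected near 2500 nM, with an estimated range of 1100 nM to 5500 nM. This estimate means an expected 1.1-fold higher number from compound 3 to compound 4 (0.06 log units; within the scatter).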

Compound 4, half-maximal inhibitory concentration: 3920 nM
The estimate for compound 4 lay 1.6-fold (0.20 log units) below the measured number; measured number inside the range.
By their numbers in this assay, from the lowest: compounds 3, 1, 4 and 2 (each within the scatter of the next).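

In this assay, the step of a 1.8-fold higher number from compound 3 to compound 4 (0.25 log units; within the scatter) moves only the methyl, giving 2-methylphenyl in place of 4-methylphenyl, and this shift of a group around the ring stays within the scatter. The steps of a 1.1-fold lower number from compound 2 to compound 4 (0.03 log units; within the scatter) and a 1.3-fold higher number from compound 1 to compound 4 (0.12 log units; within the scatter) also stay within it, so compound 4 cannot be told apart from the other three compounds. No measurement here offers an explanation for this result. Still open, on these data alone, is whether a carboxylic acid or an amine in place of the methyl would give a number beyond the scatter.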